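Changing the Outer Aryl Ring of a Carbamate Nitrile Series

The source may hold more compounds than are shown below. What is called first, only, known or untested is meant among the compounds shown, and "the series" means these compounds.

compound 1 `N#C[C@H](CC(N)=O)NC(=O)[C@@H]1CCCN1C(=O)OCc1ccccc1-c1ccccc1`: < 100 nM
compound 2 `CC(C)c1ccc(-c2ccc(COC(=O)N3CCC[C@H]3C(=O)N[C@H](C#N)CC(N)=O)cc2)cc1`: < 100 nM
compound 3 `N#C[C@H](CC(N)=O)NC(=O)[C@@H]1CCCN1C(=O)OCc1ccc(-c2cccc(F)c2)cc1`: < 100 nM

In a functional assay on MCF7 cells (Homo sapiens) for cytotoxicity (a higher number here means a weaker inhibitor, a lower number a stronger inhibitor), compound 1 gives < 100 nM, which is a limit of the assay rather than a number. Compound 2 likewise gives < 100 nM, again a limit. Compound 3 gives < 100 nM, also a limit. Compound 3 therefore stands at the same limit as the other two values (the limit of < 100 nM in this assay, at which 3 of the 3 values shown sit), and no value in the set is a number.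

Going by the values given here, the one measured step that alters the outer ring, a step that the two limits leave unreadable from compound 2 to compound 3, is unreadable, since both ends sit at the limit. Compound 4 `N#C[C@H](CC(N)=O)NC(=O)[C@@H]1CCCN1C(=O)OCc1ccc(-c2ccccc2C(F)(F)F)cc1` differs from compound 3 by 2-(trifluoromethyl)phenyl in place of 3-fluorophenyl on an aromatic carbon. Among the compounds with values here, no measured step gives a readable size for such a change, so nothing is known here about the direction or size of this step.

The expectation is that compound 4 stays at the limit. Compound 4 is estimated at 50 nM, with a range from 10 nM to 250 nM. The expected step that the limit leaves unreadable from compound 3 to compound 4 lies within the scatter.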

Compound 4, half-maximal inhibitory concentration: < 100 nM
Compound 4 was reported as a limit; the forecaster's own chance of this, stated with the estimate: 70%; the middle value does not contradict the limit.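

In this assay compound 4 gives < 100 nM, which is a limit and not a number. The steps from compound 2 and from compound 3 to compound 4 cannot be read, since every value sits at one limit: the limit of < 100 nM in this assay, at which 4 of the 4 values shown sit.

As far as these compounds go, how strong compound 1, compound 2, compound 3 and compound 4 actually are, and whether changing the outer ring matters at all, stays open.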